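Swapping a Trimethylpyrazole for a Dimethylisoxazole on a Shared Core

A few compounds are considered here, and "the series" means these few. Any claim that something is new, unique, unknown or untested is made for them only; others in the source may bear on it.

Compound 1 `CN(Cc1ccc2nccn2c1)c1nnc(-c2ccc(-c3ccccc3)cc2)o1` gives 39.8 nM in an assay on isolated protein for inhibition of tyrosine-protein kinase Mer (Homo sapiens), read by LC-MS; a higher number here means a weaker inhibitor, a lower number a stronger inhibitor.
Compound 2 `CN(Cc1ccc2nccn2c1)c1nnc(-c2ccc(-c3ccccc3C#N)cc2)o1` gives 25.1 nM in this assay.
Compound 3 `Cc1nn(C)c(C)c1-c1ccc(-c2nnc(N(C)Cc3ccc4nccn4c3)o2)cc1` gives 31.6 nM in this assay.

The three measured compounds share one core and differ only in the group attached to the outer end of the shared core. Compound 3 stands second highest of the three numbers, with compound 2 nearest and compound 1 furthest, and every step between them lies within the scatter: a 1.6-fold lower number from compound 1 to compound 2 (0.20 log units; within the scatter), a 1.3-fold lower number from compound 1 to compound 3 (0.10 log units; within the scatter) and a 1.3-fold higher number from compound 2 to compound 3 (0.10 log units; within the scatter). In other words, exchanging a phenyl, a 2-cyanophenyl or a 1,3,5-trimethyl-1H-pyrazol-4-yl at this position has so far not moved the number beyond what repeated measurements would show on their own.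

Compound 4 `Cc1noc(C)c1-c1ccc(-c2nnc(N(C)Cc3ccc4nccn4c3)o2)cc1` is the next step from compound 3, and the change is 3,5-dimethyl-1,2-oxazol-4-yl in place of 1,3,5-trimethyl-1H-pyrazol-4-yl on an aromatic carbon. Among the compounds with values here, the steps that bear on it are the two that already exchange this same group, a 1.3-fold lower number from compound 1 to compound 3 (0.10 log units; within the scatter) and a 1.3-fold higher number from compound 2 to compound 3 (0.10 log units; within the scatter), both within the scatter. A small five-membered heteroaryl with two hetero atoms replaces another of the same kind, so no step beyond the scatter is expected in this assay: the expected step is a 1.1-fold higher number from compound 3 to compound 4 (0.04 log units; within the scatter). Compound 4 is therefore expected to give 35 nM, with a range from 15 nM to 80 nM.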

Compound 4, half-maximal inhibitory concentration: 200 nM
Compound 4: middle estimate off by 5.7-fold (0.76 log units), on the low side; measured number above the stated range.
By their numbers in this assay, from the lowest: compounds 2, 3 and 1 (each within the scatter of the next); then compound 4.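

Until now this position seemed indifferent to the group placed on it, but in this assay the 3,5-dimethyl-1,2-oxazol-4-yl group separates from all three others, giving a 6.3-fold higher number from compound 3 to compound 4 (0.80 log units; beyond the scatter), an 8.0-fold higher number from compound 2 to compound 4 (0.90 log units; beyond the scatter) and a 5.0-fold higher number from compound 1 to compound 4 (0.70 log units; beyond the scatter), each beyond the scatter. The position therefore does respond to its group, and compound 4 is the weakest inhibitor of the four. The change also shows that matching counts do not make two groups equivalent here: both are one five-membered aromatic ring with 2 hetero atoms, 0 hydrogen-bond donors and 2 hydrogen-bond acceptors, yet they do not give the same number, and nothing available explains this gap.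

The compounds shown leave open whether the gap follows the oxygen in the ring or the extra methyl group of the 1,3,5-trimethyl-1H-pyrazol-4-yl group, a question that the 3,5-dimethyl-1H-pyrazol-4-yl group could help to separate. They also leave open how this position would respond to a group of a different kind, such as an amine or a carboxylic acid.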